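A few compounds are considered here, and "the series" means these few. Any claim that something is new, unique, unknown or untested is made for them only; others in the source may bear on it.

Compound 3 `O/N=C(/Nc1cccc(Br)c1)c1ccc2oc(COCC3CC3)cc2c1` stands at the lowest of the three numbers recorded in an assay on isolated protein for inhibition of Indoleamine 2,3-dioxygenase 1 (Homo sapiens), read by spectrophotometry (on this read-out lower numbers stand for stronger inhibition and higher numbers for weaker inhibition), giving 400 nM. Compound 1 `OCc1cc2cc(/C(=N\O)Nc3cccc(Br)c3)ccc2o1` gives 710 nM in this assay, and compound 2 `COCc1cc2cc(/C(=N\O)Nc3cccc(Br)c3)ccc2o1` gives 930 nM. The steps among these were small: a 1.3-fold higher number from compound 1 to compound 2 (0.12 log units; within the scatter), a 1.8-fold lower number from compound 1 to compound 3 (0.25 log units; within the scatter) and a 2.3-fold lower number from compound 2 to compound 3 (0.37 log units; beyond the scatter). Compound 4 `O/N=C(/Nc1cccc(Br)c1)c1ccc2oc(-c3ccccc3)cc2c1` carries phenyl in place of (cyclopropylmethoxy)methyl on an aromatic carbon. Within the data shown here, none of the measured steps swaps the whole side chain for an aromatic ring, so they bear only loosely on this change; all three showed that varying that position shifted the number little. Compound 4 is therefore expected to land near compound 3, as in a 1.3-fold higher number from compound 3 to compound 4 (0.10 log units; within the scatter). The estimate for compound 4 in this assay is 500 nM, ranging from 150 nM to 1600 nM.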

Compound 4, half-maximal inhibitory concentration: 900 nM
For compound 4 the middle estimate is 1.8-fold (0.26 log units) below the measured one, within the range that was stated.
By their numbers in this assay, from the lowest: compounds 3, 1, 4 and 2 (each within the scatter of the next, the first and the last beyond it).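

In this assay, among these compounds, an aromatic ring placed directly on the aromatic carbon next to the ring oxygen kept the compound in the same range as the chains, with phenyl in place of (cyclopropylmethoxy)methyl giving a 2.3-fold higher number from compound 3 to compound 4 (0.35 log units; beyond the scatter) as the one step of this change beyond the scatter. Against the smaller chains, the same swap reads a 1.0-fold lower number from compound 2 to compound 4 (0.01 log units; within the scatter) and a 1.3-fold higher number from compound 1 to compound 4 (0.10 log units; within the scatter) with neither step beyond the scatter. On these data alone, whether an amine, a carboxylic acid or a substituted phenyl at this carbon would shift the number stays open. Nothing at hand accounts for these steps.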